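This account rests on a few compounds, and the source may have more. Where it says the series, first, only, none or still open, it means among the compounds named here.

Compound 3 `CC(=O)Nc1nc(CN=C=S)cs1` is the acetyl amide of the shared core. In a functional assay on L1210 cells (Mus musculus) for antiproliferative activity (a lower number here means a stronger inhibitor, a higher number a weaker inhibitor), compound 3 gives 5200 nM, the lowest of the two numbers shown. Among the compounds with values here, compound 2 `Nc1nc(CN=C=S)cs1` gives 26000 nM, and the step of a 5.0-fold lower number from compound 2 to compound 3 (0.70 log units; beyond the scatter) is the only measured change. Compound 1 `CC(=O)Nc1nc(CCl)c[se]1` shows only a limit, > 100000 nM (the limit of > 100000 nM in this assay, at which 1 of the 3 values shown sits). Compound 4 `CCC(=O)Nc1nc(CN=C=S)cs1` differs from compound 3 by methyl in place of hydrogen on a saturated chain carbon bound to a carbonyl carbon. Within the data shown here, no measured step touches that carbon; the step from compound 2 to compound 3 concerns the presence of the amide, not its length. The change is therefore expected to give no step beyond the scatter in this assay, a 1.0-fold lower number from compound 3 to compound 4 (0.02 log units; within the scatter). For compound 4 the estimate is 5000 nM, between 2000 nM and 12000 nM.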

Compound 4, half-maximal inhibitory concentration: 6800 nM
Beside the measured number, compound 4's estimate is 1.4-fold (0.13 log units) below it, and the stated range covers the measured number.
By their numbers in this assay, from the lowest: compounds 3 and 4 (each within the scatter of the next); then compound 2. At a limit, above all of these: compound 1.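

In this assay, the step from acetyl to propanoyl stays within the scatter: a 1.3-fold higher number from compound 3 to compound 4 (0.12 log units; within the scatter) is the reading for methyl in place of hydrogen on a saturated chain carbon bound to a carbonyl carbon. The lower number relative to the unacylated nitrogen also holds for this second amide, with a 3.8-fold lower number from compound 2 to compound 4 (0.58 log units; beyond the scatter) beyond the scatter. Nothing at hand bears on a cause for either step.

Open, from the compounds shown here alone, is whether a longer chain on the carbonyl carbon, such as butanoyl, keeps the number within the scatter. Also open, going by these compounds, is what a benzoyl group would give on the same nitrogen.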